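Trading a chlorobenzyl for an allyl: cytotoxicity outlook

The source may report more compounds than this note shows. Statements on the series, on what has been measured and on what is new or still open speak of the compounds shown alone.

In an ADME assay on HEL cells (Homo sapiens) for cytotoxicity, with a stated time of 3 days (a lower number here means that less compound is tolerated, a higher number that more compound is tolerated), compound 1 `CCC1(Cc2ccccc2)OS(=O)(=O)C=C1OCc1ccc(OC)cc1` gives only a limit, > 200000 nM. Compound 2 `CCC1(Cc2ccccc2)OS(=O)(=O)C=C1OCc1ccc(Cl)cc1` likewise gives only a limit, > 200000 nM. The step that the two limits leave unreadable from compound 1 to compound 2 cannot be read, since both values sit at the same limit (the limit of > 200000 nM in this assay, at which 2 of the 2 values shown sit). Compound 3 `C=CCOC1=CS(=O)(=O)OC1(CC)Cc1ccccc1` differs from compound 2 by vinyl in place of 4-chlorophenyl on a saturated chain carbon bound to an oxygen on an unsaturated carbon. Within the data shown here, no measured step tells the size of this change, so no step beyond the scatter is expected in this assay, and the expected step of a number no higher from compound 2 to compound 3 (the limit leaves the size open) is close to none. Compound 3 is therefore expected at about 200000 nM, with a range from 60000 nM to 600000 nM.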

Compound 3, half-maximal cytotoxic concentration: > 200000 nM
Compound 3 ended at the assay's limit; the forecaster's own chance of this, stated with the estimate: 80%; the middle value lies on the limit itself.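

No size can be read for the steps from compound 2 to compound 3 or from compound 1 to compound 3, because compounds 1, 2 and 3 all give only a limit: the limit of > 200000 nM in this assay, at which 3 of the 3 values shown sit. The compounds shown leave open whether these group changes alter how much compound the cells tolerate.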